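Methoxy to propyl at the same aromatic carbon

This account rests on a few compounds, and the source may have more. Where it says the series, first, only, none or still open, it means among the compounds named here.

Compound 2 `COc1ccc(-c2cc(OC)cc(C(=O)Nc3nn[nH]n3)n2)cc1` gives 60% in a functional assay on the whole organism with Rattus norvegicus as the target, at a dose of 3 mg/kg by the oral route; on this read-out lower numbers stand for a weaker effect and higher numbers for a stronger effect at the one dose given. Among the compounds with values here, compound 2 stands lowest of the two numbers measured so far; the nearest is compound 1 `COc1cc(C(=O)Nc2nn[nH]n2)nc(-c2ccccc2)c1`, which in this assay gives 97%. Within the data shown here, the single measured step, a number 37 percentage points lower from compound 1 to compound 2 (beyond the scatter), concerns the same aromatic carbon as the change now in question. Compound 3 `CCCc1ccc(-c2cc(OC)cc(C(=O)Nc3nn[nH]n3)n2)cc1` differs from compound 2 by propyl in place of methoxy on an aromatic carbon. Among the measured compounds shown here, no measured step exchanges one substituent for another at this carbon; the only step that touches the place, methoxy in place of hydrogen, moved the number downward well beyond the scatter. Whether propyl behaves there like methoxy or like hydrogen cannot be read from these two compounds, so a move in either direction is possible and the band is wide. Compound 3 is therefore expected to give about 55%, with a range from 25% to 85%. The expected step, a number 5 percentage points lower from compound 2 to compound 3 (within the scatter), is not beyond the scatter.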

Compound 3, a percentage reported as inhibition, in the whole organism at one dose (the size of the read-out at that dose, not a potency): 93%
Beside the measured number, compound 3's estimate is 38 percentage points below it; the measured number lies above the stated range.
By their numbers in this assay, from the lowest: compound 2; then compounds 3 and 1 (each within the scatter of the next).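

In this assay, within the data shown here, the step of a number 33 percentage points higher from compound 2 to compound 3 (beyond the scatter) is the first exchange of one substituent for another at this aromatic carbon, and it shows that the read-out depends on which group sits there, not merely on whether the carbon is substituted. The step of a number 4 percentage points lower from compound 1 to compound 3 (within the scatter) lies within the scatter, so this read-out does not separate propyl from hydrogen on this carbon, and of the three groups only methoxy stands apart. Substitution at this carbon therefore carries no measurable loss as such, at least with propyl, at the one dose given.

From the compounds shown here alone, whether the low number belongs to methoxy alone remains open, and an amine, a carboxylic acid or a longer chain such as butyl on this carbon would test that. No data at hand bear on a cause for the gap between methoxy and propyl.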